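The source may report more compounds than this note shows. Statements on the series, on what has been measured and on what is new or still open speak of the compounds shown alone.

Measured compounds: compound 1 `Cc1ccccc1S(=O)(=O)c1ccc(CNC(=O)c2cc3cnccc3[nH]2)cc1` gives 12 nM; compound 2 `O=C(NCc1ccc(S(=O)(=O)c2ccccc2)cc1)c1ccc2cnccc2c1` gives > 10000 nM; compound 3 `O=C(NCc1ccc(S(=O)(=O)N2CCCCC2)cc1)c1ccc2nc[nH]c2c1` gives 310 nM.

In an assay for inhibition of Nicotinamide phosphoribosyltransferase (Homo sapiens), read by mass spectrometry, with stated times of 15 min and 30 min (on this read-out lower numbers stand for stronger inhibition and higher numbers for weaker inhibition), compound 1 gives 12 nM, the lowest of the two numbers recorded. The nearest number, that of compound 3, which gives 310 nM, lies beyond the scatter above it. Compound 2 gives only a limit of this assay, > 10000 nM; the line the limit of > 10000 nM in this assay, at which 1 of the 3 values shown sits, records that one of the three values sits there. Within the data shown here, no two of the measured compounds differ in a single place, so no measured step is available.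

Compound 4 `Cc1cccc(S(=O)(=O)c2ccc(CNC(=O)c3cc4cnccc4[nH]3)cc2)c1` has not yet been measured. It differs from compound 1 by 3-methylphenyl in place of 2-methylphenyl on a sulfonyl sulfur; in words, 3-methylphenyl stands in place of 2-methylphenyl on the sulfonyl sulfur. With the rest of the molecule kept, the step from compound 1 to compound 4 in this assay is expected to be small, if anything a slight rise, a 1.7-fold higher number from compound 1 to compound 4 (0.22 log units; within the scatter). Compound 4 is therefore estimated to give about 20 nM, with a range from 6 nM to 80 nM.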

Compound 4, half-maximal inhibitory concentration: 8 nM
Compound 4: the middle estimate sits 2.5-fold (0.40 log units) above what was measured; the measured number falls inside the stated range.
By their numbers in this assay, from the lowest: compounds 4 and 1 (each within the scatter of the next); then compound 3. At a limit, above all of these: compound 2.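

Among these compounds, the first step that changes only one place shows that, in this assay, 3-methylphenyl in place of 2-methylphenyl on the sulfonyl sulfur gives a 1.5-fold lower number from compound 1 to compound 4 (0.18 log units; within the scatter). On the core of compound 1, the two methylphenyl groups therefore cannot be told apart in this assay, and this exchange on the sulfonyl sulfur leaves the inhibition in the same range. No measurement given here offers an explanation for this result.

Going by these compounds, it remains open whether a plain phenyl, a 4-methylphenyl, or a ring carrying an amine or a carboxylic acid on the sulfonyl sulfur would give similar numbers with the same core. Compound 2 and compound 3 each differ from compound 1 in more than one place, so the separate contributions of the core and the sulfonyl substituent also stay unresolved.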